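The compounds below may be only part of what the source reports. "The series", "measured", "known", "first", "only" and "open" are said of these compounds alone.

Working notes on the series built on the core of compound 1 `CC(=O)Nc1ccc(-c2nc3cc(C(F)(F)F)ccc3n2C)cc1`. In an ADME assay on BHK cells (Mesocricetus auratus) for cytotoxicity, read by MTT assay, with a stated time of 96 h (on this read-out higher numbers stand for lower toxicity in this test and lower numbers for higher toxicity in this test), compound 1 gives > 100000 nM, a limit of the assay rather than a number. Compound 1 therefore stands at the limit of > 100000 nM in this assay, at which 1 of the 3 values shown sits, on the numbers shown. Compound 2 `CC(=O)Nc1ccc(-c2nc3cc(C(F)(F)F)ccc3n2C2CCCCC2)cc1` gives 15000 nM in this assay, and compound 3 `CC(=O)Nc1ccc(-c2nc3cc(C(F)(F)F)ccc3[nH]2)cc1` gives 53000 nM. The measured steps, an at least 6.6-fold lower number from compound 1 to compound 2 (0.82 log units; beyond the scatter), an at least 1.8-fold lower number from compound 1 to compound 3 (0.27 log units; that floor lies within the scatter) and a 3.5-fold higher number from compound 2 to compound 3 (0.55 log units; beyond the scatter), all alter the group on the aromatic nitrogen. Compound 4 `Cn1c(-c2ccc(NC(=O)CN3CCCCC3)cc2)nc2cc(C(F)(F)F)ccc21` differs from compound 1 at another place: piperidin-1-yl in place of hydrogen on a saturated chain carbon bound to a carbonyl carbon. Among the measured compounds shown here, no measured step touches this place, so no direction can be drawn from the series. The expected step from compound 1 is a number no higher from compound 1 to compound 4 (the limit leaves the size open), not beyond the scatter. Compound 4 is estimated at 100000 nM, with a range from 30000 nM to 300000 nM.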

Compound 4, half-maximal cytotoxic concentration: > 100000 nM
Compound 4 was reported as a limit; the forecaster's own chance of this, stated with the estimate: 55%; the middle value lies on the limit itself.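

In this assay, the step between compound 1 and compound 4 cannot be read, as both values are limits of the assay and not numbers: the limit of > 100000 nM in this assay, at which 2 of the 4 values shown sit. The compounds shown leave open whether piperidin-1-yl in place of hydrogen on a saturated chain carbon bound to a carbonyl carbon changes this read-out at all.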